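The source may hold more compounds than are shown below. What is called first, only, known or untested is meant among the compounds shown, and "the series" means these compounds.

Measured in a functional assay on cells (Cancer cell lines, Homo sapiens) for cytotoxicity, read by sulforhodamine B assay, with a stated time of 48 h; a lower number here means a stronger inhibitor of growth, a higher number a weaker inhibitor of growth:

compound 1 `COc1ccc(C2CC(c3ccccc3)=NN2C2=NC(=O)/C(=C3\C(=O)Nc4ccc(Br)cc43)S2)cc1` — 660 nM
compound 2 `COc1ccc(C2=NN(C3=NC(=O)/C(=C4\C(=O)Nc5ccc(Br)cc54)S3)C(c3ccc(OC)cc3)C2)cc1` — 710 nM
compound 3 `O=C1N=C(N2N=C(c3ccccc3)CC2c2ccc(Cl)cc2)S/C1=C1/C(=O)Nc2ccccc21` — 850 nM

All three values lie close together; compound 3 gives the highest number of the three, but its distance from compound 2 and from compound 1 is within the scatter, so no order among them is claimed.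

One structural change has a measured step. Compound 1 and compound 2 differ by methoxy in place of hydrogen on an aromatic carbon and the step is a 1.1-fold higher number from compound 1 to compound 2 (0.03 log units; within the scatter).

Compound 4 `COc1ccc(C2=NN(C3=NC(=O)/C(=C4\C(=O)Nc5ccccc54)S3)C(c3ccc(Cl)cc3)C2)cc1` is not yet measured. It differs from compound 3 by methoxy in place of hydrogen on an aromatic carbon, the same change as between compound 1 and compound 2, at a place described in the same words. The difference between the core of compound 3 and the core of compound 1 is not broken down here.

For compound 4 the step is expected to be a 1.1-fold higher number from compound 3 to compound 4 (0.02 log units; within the scatter), resting on a 1.1-fold higher number from compound 1 to compound 2 (0.03 log units; within the scatter), which sat within the scatter. The value of compound 4 in this assay is estimated at 900 nM, between 500 nM and 1700 nM.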

Compound 4, concentration for total growth inhibition: 100000 nM
Compound 4: the middle estimate sits 110-fold (2.05 log units) below what was measured, outside the stated range (above it).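

Methoxy in place of hydrogen on an aromatic carbon, para to a large group, does not carry over unchanged between these two cores in this assay; on the core of compound 3 the change gives a 120-fold higher number from compound 3 to compound 4 (2.07 log units; beyond the scatter). The same change therefore has two different outcomes, one within the scatter and one far beyond it: the same change on two cores in this assay, a 1.1-fold higher number (0.03 log units; within the scatter) from compound 1 to compound 2 and a 120-fold higher number (2.07 log units; beyond the scatter) from compound 3 to compound 4, 110-fold (2.04 log units) apart, beyond the scatter of two such steps

This shows that, for these two pairs, the step measured on one core cannot be transferred to the other, but it does not show which part of the cores is responsible, nor why the step is so large, and two pairs establish no rule for the series. The cores of compound 1 and compound 3 differ in more than one place, and the compounds shown do not separate those differences. Also open, going by these compounds, is whether a different group on the same aromatic carbon, such as an amine, a carboxylic acid or a longer alkoxy chain, would follow compound 4 or compound 3 on this core.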